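Notes on the pyridine substituent step in the series

A few compounds are considered here, and "the series" means these few. Any claim that something is new, unique, unknown or untested is made for them only; others in the source may bear on it.

Among the compounds with values here, in an assay on T-REx-293 cells for inhibition of potassium channel subfamily T member 1 (Homo sapiens), read by patch clamp (a lower number here means a stronger inhibitor, a higher number a weaker inhibitor), compound 2 `COCc1cc(-c2noc([C@H](C)NC(=O)c3cc(C(F)(F)F)nn3C)n2)ccn1` gives 322 nM, the lower of the two numbers measured so far, with compound 1 `C[C@H](NC(=O)c1cc(C(F)(F)F)nn1C)c1nc(-c2ccnc(N3CCCC3)c2)no1` at 573 nM within the scatter of it. Within the data shown here, the only step measured, a 1.8-fold lower number from compound 1 to compound 2 (0.25 log units; within the scatter), replaced one group with another on the same aromatic carbon and stayed within the scatter. Compound 3 `CNc1cc(-c2noc([C@H](C)NC(=O)c3cc(C(F)(F)F)nn3C)n2)ccn1` differs from compound 2 by methylamino in place of methoxymethyl on an aromatic carbon. Among the measured compounds shown here, the exchange lies at the position where the measured step produced no change beyond the scatter, so the one step that bears on it gives no ground for expecting a shift in this assay in either direction; the change from methoxymethyl to methylamino has no precedent of its own. Compound 3 is therefore estimated at 320 nM, with a range of 120 nM to 850 nM. The expected step reads a 1.0-fold lower number from compound 2 to compound 3 (0.00 log units; within the scatter), within the scatter.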

Compound 3, half-maximal inhibitory concentration: 195 nM
For compound 3 the middle estimate is 1.6-fold (0.22 log units) above the measured one; the range from low to high includes it.
By their numbers in this assay, from the lowest: compounds 3, 2 and 1 (each within the scatter of the next, the first and the last beyond it).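

In this assay, methylamino in place of methoxymethyl on this aromatic carbon gives a 1.7-fold lower number from compound 2 to compound 3 (0.22 log units; within the scatter), so a second exchange at the position stays within the scatter, this time with a group that carries a hydrogen-bond donor. Methylamino in place of pyrrolidin-1-yl gives a 2.9-fold lower number from compound 1 to compound 3 (0.47 log units; beyond the scatter), the first step in the series beyond the scatter, so the position is not indifferent to what sits on it, although the effect is modest and compound 2 lies within the scatter of both neighbours. Nothing available explains this difference.

Open, on these data alone, is how the plain amino group, dimethylamino or a longer chain such as ethylamino would compare with methylamino here. Only this one position varies among the compounds shown, so the response of the rest of the shared core also remains open.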